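Mirror-image change at the single stereocentre of compound 2

The compounds below may be only part of what the source reports. "The series", "measured", "known", "first", "only" and "open" are said of these compounds alone.

Measured so far:
compound 1, `Clc1ccc([C@H](CCn2cncn2)Cc2ccccc2)cc1`, gives 21.7 ug/mL
compound 2, `C[C@@H](CCn1cncn1)Cc1ccccc1`, gives 114 ug/mL

The study follows the step from compound 2 to compound 3. In an ADME assay on RD cells (Homo sapiens) for cytotoxicity, read by MTT assay, with a stated time of 3 days (on this read-out lower numbers stand for higher toxicity in this test and higher numbers for lower toxicity in this test), compound 2 stands with the highest of the two numbers; its nearest neighbour, compound 1, gives 21.7 ug/mL, which is a gap beyond the usual scatter, so compound 2 shows the lower toxicity of the two.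

Compound 3 is `C[C@H](CCn1cncn1)Cc1ccccc1`. Its difference from compound 2 is the two compounds have the same atoms and bonds and differ only in configuration as drawn: 1 of 1 stereo elements differ; a stereocentre at a saturated chain carbon is drawn R in compound 2 and S in compound 3. Within the data shown here, no pair of measured compounds differing in one place is available, so the size of such a step has not been seen. Since the atoms and bonds are identical and only the drawn configuration changes, the expected step in this assay is none beyond the scatter, in no particular direction. Compound 3 is therefore estimated at 110 ug/mL, with a range from 55 ug/mL to 230 ug/mL, which corresponds to an expected step of a 1.0-fold lower number from compound 2 to compound 3 (0.02 log units; within the scatter).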

Compound 3, half-maximal cytotoxic concentration: 153 ug/mL
The estimate for compound 3 lay 1.4-fold (0.14 log units) below the measured number; low and high end bracket the measured number.
By their numbers in this assay, from the lowest: compound 1; then compounds 2 and 3 (each within the scatter of the next).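

In this assay, the mirror-image change at the saturated chain carbon gives a 1.3-fold higher number from compound 2 to compound 3 (0.13 log units; within the scatter), so with methyl on this carbon the drawn configuration, R or S, does not separate the two compounds in this test. The comparison rests on a single structural difference: the fact that compounds 2 and 3 differ only in the configuration as drawn

Methyl in place of 4-chlorophenyl on this carbon gives a 7.1-fold higher number from compound 1 to compound 3 (0.85 log units; beyond the scatter), and this first step between compounds differing in one place shows that the group on this carbon, unlike its configuration here, moves the read-out beyond the scatter.

As far as these compounds go, it remains open whether configuration at this carbon would also leave the number unchanged with 4-chlorophenyl in place of methyl. From the compounds shown here alone, it is also open where an ethyl group, an unsubstituted phenyl or an amine on this carbon would fall in this assay.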